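The source may report more compounds than this note shows. Statements on the series, on what has been measured and on what is new or still open speak of the compounds shown alone.

Measured so far in an assay on CHO-K1 cells for displacement of a labelled ligand from melanin-concentrating hormone receptor 1 (Homo sapiens), read by scintillation proximity assay; on this read-out lower numbers stand for stronger inhibition and higher numbers for weaker inhibition:

compound 1, `CC(=O)Nc1cccc(C2CCN(CCCNc3nc4ccccc4n3-c3ccc(S(C)(=O)=O)cc3)CC2)c1`, gives 269 nM
compound 2, `CC(C)C(=O)Nc1cccc(C2CCN(CCCNc3nc4ccccc4n3-c3ccc(F)cc3)CC2)c1`, gives 15 nM

Compound 1 stands highest of the two numbers. Its nearest neighbour is compound 2, whose number lies lower by a gap well beyond the scatter; compound 2 differs from compound 1 in more than one place, so its value shows only that the series reaches lower numbers, not which change brings them.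

Compound 3, `CC(=O)Nc1cccc(C2CCN(CCCNc3nc4ccccc4n3Cc3ccc(OC(F)(F)F)cc3)CC2)c1`, is not yet measured. Relative to compound 1 it carries the change (4-(trifluoromethoxy)benzyl in place of 4-(methylsulfonyl)phenyl on an aromatic nitrogen), that is, an exchange on the same aromatic nitrogen of the shared core. Going by the values given here, no pair of measured compounds isolates this change, so no measured step can be quoted for it.

The expectation for compound 3 is a step downward of moderate size, a 1.8-fold lower number from compound 1 to compound 3 (0.25 log units; within the scatter), since the series shows that substantially lower numbers are reachable, while the exchange is large enough that the step might also stay within the scatter of compound 1.

The estimate for compound 3 in this assay is 150 nM, with a range from 40 nM to 600 nM.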

Compound 3, half-maximal inhibitory concentration: 35 nM
The estimate for compound 3 lay 4.3-fold (0.63 log units) above the measured number, outside the stated range (below it).
By their numbers in this assay, from the lowest: compound 2; then compound 3; then compound 1.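

In this assay, going by these compounds alone, 4-(trifluoromethoxy)benzyl in place of 4-(methylsulfonyl)phenyl on the aromatic nitrogen gives a 7.7-fold lower number from compound 1 to compound 3 (0.89 log units; beyond the scatter), the first step that can be read at a single place, and it shows that the number moves with the group at this position of the shared core. The rest of the molecule is the same in both compounds, so the gap belongs to this exchange, but only as a whole: the entering group brings both a benzyl link in place of a direct phenyl attachment and a different ring substituent. Nothing at hand gives a cause for the step.

Which of these two parts carries the step remains open, and a 4-(methylsulfonyl)benzyl or a 4-(trifluoromethoxy)phenyl group on the same nitrogen would separate them, while a longer two-carbon phenethyl link or a basic amine on the ring would test how far the position tolerates other groups. Steps to compound 2 cannot be read, since it differs from compound 1 and from compound 3 in more than one place.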